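From Nitro to Tert-Butyl: An Expectation for Compound 4

The compounds below may be only part of what the source reports. "The series", "measured", "known", "first", "only" and "open" are said of these compounds alone.

Of the compounds shown here, three built on one shared core have been tested in a functional assay on ileum (strain Hartley) for agonist activity at 5-hydroxytryptamine receptor 3A (Cavia porcellus); on this read-out lower numbers stand for lower potency and higher numbers for higher potency (the scale is a negative logarithm). Compound 1 `CN1CCN(c2nc3cc([N+](=O)[O-])ccc3o2)CC1` gives 6.1, the second highest of the three numbers. Compound 2 `CCc1cc(C)cc2nc(N3CCN(C)CC3)oc12` gives 6.46, a higher number, and compound 3 `CN1CCN(c2nc3cccc(Cl)c3o2)CC1` gives 5.5, a lower one; both gaps to compound 1 lie beyond the usual scatter. Compound 4 `CN1CCN(c2nc3cc(C(C)(C)C)ccc3o2)CC1` has not yet been measured. It differs from compound 1 in one place: tert-butyl in place of nitro on an aromatic carbon. For the measured compounds named here, no measured pair of compounds shows this particular change, so there is no directly comparable step to lean on. In this assay the expected step is a number 0.10 log units lower from compound 1 to compound 4 (within the scatter), a change not beyond the scatter. Compound 4 is therefore estimated to give about 6, within a range from 5.4 to 6.6.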

Compound 4, negative logarithm of the half-maximal effective concentration: < 4
Compound 4 ended at the assay's limit (the forecaster's own chance of this, stated with the estimate: 5%); middle value at least 2.00 log units away from the limit.
By their numbers in this assay, from the lowest: compound 3; then compound 1; then compound 2. At a limit, below all of these: compound 4.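

In this assay compound 4 gives < 4, which is a limit of the assay and not a number. Tert-butyl in place of nitro on this aromatic carbon gives a number at least 2.10 log units lower from compound 1 to compound 4 (beyond the scatter), so the earlier compounds' narrow spread of values does not carry over to every group at this place. This step is a bound and not an exact size: the limit of < 4 in this assay, at which 1 of the 4 values shown sits.

Only nitro and tert-butyl are shown at this place, so it stays open what an amine or a nitrile would give there. On these data alone, it also stays open how far compound 4 lies beyond its limit.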